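Cytotoxicity notes on an aryl-oxazole piperidine amide series

The compounds below may be only part of what the source reports. "The series", "measured", "known", "first", "only" and "open" are said of these compounds alone.

Measured so far:
compound 1 `Cc1ccccc1-c1nc(CN2CCC(C(=O)NCCCN3CC(C)(C)CC(C)(C)C3)CC2)c(C)o1` — 4380 nM
compound 2 `Cc1oc(-c2c(Cl)cccc2Cl)nc1CN1CCC(C(=O)NCCCN2C[C@H](C)C[C@H](C)C2)CC1` — 13200 nM

Among the measured compounds shown here, in an ADME assay on Huh7.5.1 cells (Homo sapiens) for cytotoxicity, read by ATP content, with a stated time of 48 h (a higher number here means that more compound is tolerated, a lower number that less compound is tolerated), compound 2 gives 13200 nM, the highest of the two numbers so far. For the measured compounds named here, compound 1 gives 4380 nM in this assay, a lower number beyond the usual scatter; no single-point step connects the two, so the gap is only read as the two values show it.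

Compound 3 `COc1cccc(OC)c1-c1nc(CN2CCC(C(=O)NCCCN3C[C@H](C)C[C@H](C)C3)CC2)c(C)o1` is not yet measured. Relative to compound 2 the change is 2,6-dimethoxyphenyl in place of 2,6-dichlorophenyl on an aromatic carbon. Going by the values given here, no step of this kind between measured compounds is available, so the direction is open. With both measured numbers sitting in the same broad region of this assay, the step from compound 2 to compound 3 is expected to be small, likely none beyond the scatter, and if anything somewhat downward: a 1.5-fold lower number from compound 2 to compound 3 (0.17 log units; within the scatter). For compound 3 the estimate in this assay is therefore 9000 nM, with a range from 3500 nM to 25000 nM.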

Compound 3, half-maximal cytotoxic concentration: 77100 nM
Compound 3: middle estimate off by 8.6-fold (0.93 log units), on the low side, and the stated range ends below it.
By their numbers in this assay, from the lowest: compound 1; then compound 2; then compound 3.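

Among the compounds shown here, this is the first single-point step. In this assay, for the compounds shown here, 2,6-dimethoxyphenyl in place of 2,6-dichlorophenyl gives a 5.8-fold higher number from compound 2 to compound 3 (0.77 log units; beyond the scatter), so more compound is tolerated with only this aryl group changed, on an aromatic carbon of a five-membered aromatic ring with 1 nitrogen and 1 oxygen. Nothing available bears on the cause of this step.

A single pair leaves open whether both methoxy groups are needed, and how an unsubstituted phenyl, a 2-methoxyphenyl or a 2,6-difluorophenyl would read at the same place. As far as these compounds go, it also remains open whether the same exchange would move the number in the same direction on the amine end of compound 1, which differs from that of compound 2 and compound 3.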